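The compounds below may be only part of what the source reports. "The series", "measured", "known", "first", "only" and "open" are said of these compounds alone.

Compound 2 `CS(=O)(=O)c1ccc(-c2cnc3[nH]cc(-c4nnc(-c5ccc(Cl)cc5)o4)c(=O)c3c2)cc1` is the lower of the two numbers in a functional assay on MCF7 cells (Homo sapiens) for inhibition, read by MTT assay, with a stated time of 24 h, tested at 5 uM (a lower number here means less inhibition of growth, a higher number more inhibition of growth at the concentration tested), where compound 2 gives 0.86%. Compound 1 `CS(=O)(=O)c1ccc(-c2cnc3[nH]cc(-c4nnc(-c5ccc(F)cc5)o4)c(=O)c3c2)cc1` gives 3.78% in this assay, and the step of a number 2.9 percentage points lower from compound 1 to compound 2 (within the scatter) arose from chloro in place of fluoro on an aromatic carbon. Compound 3 `Cc1ccc(-c2nnc(-c3c[nH]c4ncc(-c5ccc(S(C)(=O)=O)cc5)cc4c3=O)o2)cc1` differs from compound 2 by methyl in place of chloro on an aromatic carbon. Within the data shown here, only that single measured step, within the scatter, bears on this change, so no step beyond the scatter is expected in this assay. The estimated step of a number 1.1 percentage points higher from compound 2 to compound 3 (within the scatter) is expected to stay within the scatter. Compound 3 is therefore expected to give 2%, between -5% and 10%.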

Compound 3, percent growth inhibition at one concentration: 6.26%
The estimate for compound 3 lay 4.3 percentage points below the measured number; the range from low to high includes it.
By their numbers in this assay, from the lowest: compounds 2, 1 and 3 (each within the scatter of the next).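

Methyl in place of chloro brings a number 5.4 percentage points higher from compound 2 to compound 3 (within the scatter) in this assay and methyl in place of fluoro brings a number 2.5 percentage points higher from compound 1 to compound 3 (within the scatter) at the same place. A carbon group on this aromatic carbon, para to a large group, thus joins the two halogens within the scatter of one another, which the fluoro and chloro pair alone could not show. On these data alone, whether an amine, a methoxy group or a carboxylic acid here would move the number beyond the scatter remains open. Nothing available explains these numbers.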